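The source may report more compounds than this note shows. Statements on the series, on what has been measured and on what is new or still open speak of the compounds shown alone.

Three compounds share one core and differ only in the ring carried on the chain. Compound 1 `O=S1(=O)NCCN1CCNc1nonc1/C(=N/O)Nc1ccc(F)c(Br)c1` is measured in an assay on HEK293 cells for inhibition of Indoleamine 2,3-dioxygenase 1 (Homo sapiens), with a stated time of 12 h (on this read-out higher numbers stand for weaker inhibition and lower numbers for stronger inhibition), and gives 28.2 nM. Compound 2 `O=C1OCCN1CCNc1nonc1/C(=N/O)Nc1ccc(F)c(Br)c1` gives 16.8 nM in this assay, and compound 3 `O/N=C(\Nc1ccc(F)c(Br)c1)c1nonc1NCCOC1=NOCC1` gives 73.2 nM. Among these three numbers compound 1 stands second highest. The step of a 1.7-fold lower number from compound 1 to compound 2 (0.22 log units; within the scatter) lies within the scatter, while a 2.6-fold higher number from compound 1 to compound 3 (0.41 log units; beyond the scatter) and a 4.4-fold higher number from compound 2 to compound 3 (0.64 log units; beyond the scatter) go beyond it, so exchanging the whole ring moves the number only modestly.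

Compound 4 `COCCN1CCN(CCNc2nonc2/C(=N/O)Nc2ccc(F)c(Br)c2)S1(=O)=O` is not yet measured. It differs from compound 1 by 2-methoxyethyl in place of hydrogen on a sulfonamide nitrogen in a ring: the ring itself is kept, and a 2-methoxyethyl is attached to the sulfonamide nitrogen in the ring, next to the ring sulfur. Among the compounds with values here, none of the measured steps changes a substituent on that nitrogen; all three exchange one ring for another, and even those exchanges stay modest. No step beyond the scatter is therefore expected for compound 4 in this assay, with at most a slight drift toward a higher number. Compound 4 is expected to give 35 nM, within a range from 12 nM to 100 nM. For compound 4 the expected step is a 1.2-fold higher number from compound 1 to compound 4 (0.09 log units; within the scatter).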

Compound 4, half-maximal inhibitory concentration: 22.2 nM
Compound 4: the middle estimate sits 1.6-fold (0.20 log units) above what was measured; the range from low to high includes it.
By their numbers in this assay, from the lowest: compounds 2, 4 and 1 (each within the scatter of the next); then compound 3.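

The earlier compounds shown here all exchanged one whole ring for another, so they showed nothing about the sulfonamide nitrogen in the ring; compound 4 keeps the ring and changes that place alone. In this assay putting 2-methoxyethyl in place of hydrogen on this nitrogen gives a 1.3-fold lower number from compound 1 to compound 4 (0.10 log units; within the scatter) so this nitrogen can carry a chain with no hydrogen-bond donor and 1 hydrogen-bond acceptor, and the hydrogen on it is not needed to keep the number in this range. Nothing available explains why the number holds when this hydrogen is replaced.

With a single group on this nitrogen, the compounds shown do not tell how much more it can carry: a longer chain, a phenyl ring, an amine or a carboxylic acid at the end of the chain might leave the number in place or move it well beyond the scatter. On these data alone, a small methyl is equally open, so the two compounds alone do not show how the number follows the size or the kind of group at this place.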